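The source may hold more compounds than are shown below. What is called first, only, known or untested is meant among the compounds shown, and "the series" means these compounds.

Measured so far in a functional assay on HeLa cells (Homo sapiens) for inhibition, read by MTT assay; a higher number here means a weaker inhibitor, a lower number a stronger inhibitor:
- compound 1, `COc1ccc(/C=N/NC(=S)N/N=C2\C(=O)Nc3ccc(C)cc32)cc1O`: 2730 nM
- compound 2, `COc1ccc(/C=N/NC(=S)N/N=C2\C(=O)Nc3ccc(Br)cc32)cc1O`: 2220 nM
- compound 3, `O=C1Nc2ccc(Br)cc2/C1=N/NC(=S)N/N=C/c1ccc2ccccc2c1`: only a limit is recorded here, > 50000 nM

Among the two numbers, compound 1 holds the higher; its nearest neighbour is compound 2, reached by a 1.2-fold lower number from compound 1 to compound 2 (0.09 log units; within the scatter), so the two stand together and no order between them is claimed. Compound 3 carries the bromo core of compound 2 with a different side group, and for compound 3 this assay returned only (the limit of > 50000 nM in this assay, at which 1 of the 3 values shown sits).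

Compound 4, `Cc1ccc2c(c1)/C(=N/NC(=S)N/N=C/c1ccccc1Br)C(=O)N2`, follows from compound 1 by 2-bromophenyl in place of 3-hydroxy-4-methoxyphenyl on a carbon with a double bond to nitrogen. Among the measured compounds shown here, no measured step covers exactly this exchange. For the measured compounds named here, the only comparison that touches the same position is the pair compound 2 and compound 3: compound 2 gives a number, compound 3 only a limit, so changing the side group away from the 3-hydroxy-4-methoxyphenyl has, in the one case recorded, moved the value out of range. The bromo-for-methyl step on the core, a 1.2-fold lower number from compound 1 to compound 2 (0.09 log units; within the scatter), is within the scatter and gives no guidance on the side group. A sizeable upward step is therefore expected for compound 4, with a real chance of a limit. The expected step is a 5.5-fold higher number from compound 1 to compound 4 (0.74 log units; beyond the scatter). Compound 4 is estimated at 15000 nM, within 4000 nM to 50000 nM.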

Compound 4, half-maximal inhibitory concentration: > 50000 nM
Compound 4 was reported as a limit (the forecaster's own chance of this, stated with the estimate: 30%); middle value at least 3.3-fold (0.52 log units) from the limit.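

In this assay the exchange gives an at least 18-fold higher number from compound 1 to compound 4 (1.26 log units; beyond the scatter), so the loss at this carbon is not confined to the bromo core: it also appears on the methyl-bearing core. The entering 2-bromophenyl keeps one six-membered aromatic ring of carbon only, so a ring of that kind at this place does not alone preserve a measured value; the change removes the hydroxy and methoxy groups and brings in bromine. Among the compounds shown here, compound 3 and compound 4 are both recorded only as limits, with different side groups on different cores, and the 3-hydroxy-4-methoxyphenyl compounds are so far the only ones here with numbers: the limit of > 50000 nM in this assay, at which 2 of the 4 values shown sit.

The compounds shown do not separate the parts of this exchange: a phenyl carrying a lone hydroxy, a lone methoxy or an amine, or a phenyl with no further group, would show whether the hydroxy, the methoxy or the bromine carries the loss. Going by these compounds, the bromo-for-methyl comparison also rests on one pair, and it remains open whether it holds with any other side group.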